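Trifluoromethyl in Place of Cyano: An Expected Step

A few compounds are considered here, and "the series" means these few. Any claim that something is new, unique, unknown or untested is made for them only; others in the source may bear on it.

Of the compounds shown here, two have been measured in an assay (Rattus norvegicus) for inhibition of Fatty-acid amide hydrolase 1 (Homo sapiens); a higher number here means a weaker inhibitor, a lower number a stronger inhibitor. Compound 1 `NS(=O)(=O)c1ccc(-c2cnc(C(=O)CCCCCCc3ccccc3)o2)s1` gives 3 nM. For the measured compounds named here, compound 2 `N#Cc1cnc(C(O)CCCCCCc2ccccc2)o1` gives 4200 nM, the higher of the two numbers, and its distance from compound 1 lies far beyond the usual scatter; no single-point step connects these two structures, so the pair shows only how far apart they sit. Compound 3 `OC(CCCCCCc1ccccc1)c1ncc(C(F)(F)F)o1` has not been measured. It differs from compound 2 in one place: trifluoromethyl in place of cyano on an aromatic carbon. No measured step of this kind exists among the compounds shown, so the expectation rests on the change alone. The expected step is small and, if anything, toward a weaker inhibitor: a 1.4-fold higher number from compound 2 to compound 3 (0.15 log units; within the scatter), within the scatter. The estimate for compound 3 in this assay is 6000 nM, with a range from 2000 nM to 18000 nM.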

Compound 3, inhibition constant: 2300 nM
Beside the measured number, compound 3's estimate is 2.6-fold (0.42 log units) above it, and the stated range covers the measured number.
By their numbers in this assay, from the lowest: compound 1; then compounds 3 and 2 (each within the scatter of the next).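

In this assay, trifluoromethyl in place of cyano on an aromatic carbon, next to the ring oxygen, gives a 1.8-fold lower number from compound 2 to compound 3 (0.26 log units; within the scatter) and so leaves the two compounds indistinguishable. For this pair, then, the position accepts either group without a measurable shift, even though the exchange removes the triple bond and the hydrogen-bond acceptor counted for cyano and brings in more heavy atoms. Nothing available explains why these two groups read alike in this assay.

Going by these compounds, whether an amine or a carboxylic acid on this same carbon would also stay within the scatter of these two compounds remains open. Also open, on these data alone, is whether this exchange would read the same with a carbonyl in place of the alcohol, the form found in compound 1.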